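The compounds below may be only part of what the source reports. "The series", "measured", "known", "first", "only" and "open" are said of these compounds alone.

Measured so far: compound 1 `O=C(COc1ccc(C(=O)/C=C/c2cccc(Cl)c2)cc1)N[C@H]1CCOC1=O`, 4990 nM; compound 2 `CC(C)(C)c1ccc(/C=C/C(=O)c2ccc(OCC(=O)N[C@H]3CCOC3=O)cc2)cc1`, 10600 nM.

Both numbers come from a functional assay on PC-3 cells (Homo sapiens) for antiproliferative activity, read by MTT assay, with a stated time of 72 h; on this read-out higher numbers stand for weaker inhibition and lower numbers for stronger inhibition. Compound 2 stands at the highest of the two numbers; its nearest neighbour is compound 1, and the step of a 2.1-fold higher number from compound 1 to compound 2 (0.33 log units; beyond the scatter) lies beyond the scatter. Compound 3 `O=C(COc1ccc(C(=O)/C=C/c2ccccc2)cc1)N[C@H]1CCOC1=O` is not yet measured in this assay. It differs from compound 2 by hydrogen in place of tert-butyl on an aromatic carbon, at a position para to a large group; cut one bond further out, the change reads 4-(tert-butyl)phenyl to phenyl. Within the data shown here, no measured step removes a substituent from this ring altogether. Among the measured compounds shown here, the only step in hand, a 2.1-fold higher number from compound 1 to compound 2 (0.33 log units; beyond the scatter), exchanges one substituted phenyl for another and gives no direct guide, beyond showing that changes on this ring move the number modestly. The expected step is therefore a 1.5-fold lower number from compound 2 to compound 3 (0.18 log units; within the scatter) in this assay, with wide uncertainty. Compound 3 is estimated at 7000 nM, with a range from 3000 nM to 20000 nM.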

Compound 3, half-maximal inhibitory concentration: 56800 nM
Compound 3: middle estimate off by 8.1-fold (0.91 log units), on the low side; measured number outside the range, above it.
By their numbers in this assay, from the lowest: compound 1; then compound 2; then compound 3.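

In this assay, compound 3, with the bare phenyl, is the weakest of the three: taking off tert-butyl gives a 5.4-fold higher number from compound 2 to compound 3 (0.73 log units; beyond the scatter), and taking off chloro gives an 11-fold higher number from compound 1 to compound 3 (1.06 log units; beyond the scatter). The earlier step between the two substituted compounds, a 2.1-fold higher number from compound 1 to compound 2 (0.33 log units; beyond the scatter), is smaller than either of these, so on the compounds shown, having a group on this ring matters more than which of the two groups it is, and none of the three goes against this. Nothing at hand bears on why the number rises when the group is lost.

Whether any group on this ring would serve as well as chloro and tert-butyl remains open, as only these two are shown. A methoxy group, an amine or a carboxylic acid at the same place would test how far this holds.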